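Expected Cytotoxicity After Swapping Isopropyl for Methylsulfonyl

This account rests on a few compounds, and the source may have more. Where it says the series, first, only, none or still open, it means among the compounds named here.

Compound 2 `COc1cc2c(=O)c(C(=O)c3ccc(C)cc3)cn(Cc3ccc(C(C)C)cc3)c2cc1OC` holds the only number shown here; in an ADME assay on Huh-7 cells (Homo sapiens) for cytotoxicity (a lower number here means a stronger inhibitor of growth, a higher number a weaker inhibitor of growth), compound 2 gives 15500 nM. Compound 1 `COc1cc2c(=O)c(C(=O)c3ccc(C)cc3)cn(Cc3ccc(S(N)(=O)=O)cc3)c2cc1OC` reaches only a limit of this assay, > 25000 nM. Among the measured compounds shown here, the single measured step, an at least 1.6-fold lower number from compound 1 to compound 2 (0.20 log units; that floor lies within the scatter), therefore rests on that limit (the limit of > 25000 nM in this assay, at which 1 of the 2 values shown sits). Compound 3 `COc1cc2c(=O)c(C(=O)c3ccc(C)cc3)cn(Cc3ccc(S(C)(=O)=O)cc3)c2cc1OC` carries the change (methylsulfonyl in place of isopropyl on an aromatic carbon), moving back toward a sulfur-bearing group like that of compound 1. Compound 3 is thus expected to shift toward weaker growth inhibition by a 1.6-fold higher number from compound 2 to compound 3 (0.21 log units; within the scatter), which may again end at the limit. Compound 3 is estimated at 25000 nM, between 12000 nM and 60000 nM.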

Compound 3, concentration for 50% growth inhibition: > 50000 nM
Compound 3 was reported as a limit; the forecaster's own chance of this, stated with the estimate: 50%; at least 2.0-fold (0.30 log units) between middle value and limit.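

Methylsulfonyl in place of isopropyl on this aromatic carbon gives, in this assay, an at least 3.2-fold higher number from compound 2 to compound 3 (0.50 log units; beyond the scatter), the first step at this position that is readable beyond the scatter. Compound 3 stands at a limit, not a number: the limit of > 50000 nM in this assay, at which 1 of the 3 values shown sits. The step between compound 1 and compound 3 cannot be read, so sulfamoyl and methylsulfonyl remain unranked here. Going by these compounds, whether an amine or a carboxylic acid on this carbon would read nearer compound 2 or reach a limit stays open. So does whether any group here would give a lower number than isopropyl.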